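The source may hold more compounds than are shown below. What is called first, only, known or untested is meant among the compounds shown, and "the series" means these compounds.

Compound 1 `N#Cc1c(Nc2ccccc2Cl)nc(SCc2cn(Cc3ccccc3Cl)nn2)nc1-c1ccccc1` gives 1950 nM in a functional assay on MCF7 cells (Homo sapiens) for inhibition, read by MTT assay, with a stated time of 72 h; a higher number here means a weaker inhibitor, a lower number a stronger inhibitor.
Compound 2 `N#Cc1c(Nc2cccc(Cl)c2)nc(SCc2cn(Cc3ccccc3Cl)nn2)nc1-c1ccccc1` gives 12000 nM in this assay.
Compound 3 `COc1ccccc1Nc1nc(SCc2cn(Cc3ccccc3Cl)nn2)nc(-c2ccccc2)c1C#N` gives 6170 nM in this assay.

Among these three numbers, compound 3 stands second highest. Its nearer neighbour lies within the scatter: a 1.9-fold lower number from compound 2 to compound 3 (0.29 log units; within the scatter). Its farther neighbour lies beyond it: a 3.2-fold higher number from compound 1 to compound 3 (0.50 log units; beyond the scatter).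

Compound 4 `Cc1cccc(Nc2nc(SCc3cn(Cc4ccccc4Cl)nn3)nc(-c3ccccc3)c2C#N)c1` has not yet been measured in this assay. It differs from compound 3 in one place: 3-methylphenyl in place of 2-methoxyphenyl on a nitrogen on an aromatic ring. Going by the values given here, two measured steps bear on this. The first moves the substituent of the anilino ring from 2-chlorophenyl to 3-chlorophenyl and weakens inhibition: a 6.2-fold higher number from compound 1 to compound 2 (0.79 log units; beyond the scatter). The second, which exchanges 3-chlorophenyl for 2-methoxyphenyl, stays within the scatter: a 1.9-fold lower number from compound 2 to compound 3 (0.29 log units; within the scatter). Among the compounds with values here, no measured step shows methyl in place of methoxy or chloro, so that part of the change is unknown. Since compound 4 carries its substituent in the same position as compound 2, a number near that of compound 2 seems the reasonable expectation, which means a modest rise from compound 3 in this assay: a 1.6-fold higher number from compound 3 to compound 4 (0.21 log units; within the scatter). Compound 4 is therefore estimated at 10000 nM in this assay, with a likely range from 4000 nM to 30000 nM.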

Compound 4, half-maximal inhibitory concentration: 19600 nM
Estimate against measurement, compound 4: 2.0-fold (0.29 log units) below, and the stated range covers the measured number.
By their numbers in this assay, from the lowest: compound 1; then compounds 3, 2 and 4 (each within the scatter of the next, the first and the last beyond it).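

In this assay, 3-methylphenyl in place of 2-methoxyphenyl on the nitrogen weakens inhibition beyond the scatter (a 3.2-fold higher number from compound 3 to compound 4 (0.50 log units; beyond the scatter)), although this single step changes both the group and its printed ring position. Methyl in place of chloro on an aromatic carbon, a change no earlier pair showed, stays within the scatter (a 1.6-fold higher number from compound 2 to compound 4 (0.21 log units; within the scatter)), so the 3-methylphenyl and 3-chlorophenyl compounds cannot be told apart here. Compound 1, with its 2-chlorophenyl group, remains the strongest inhibitor of the four, and the widest step in the set now appears with 3-methylphenyl in its place (a 10-fold higher number from compound 1 to compound 4 (1.00 log units; beyond the scatter)).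

No measurement given here accounts for any of these differences. The compounds shown leave open whether 2-methylphenyl or 3-methoxyphenyl would separate the effect of the group from that of its ring position, and how an amine, a carboxylic acid or a longer chain on this phenyl ring would read in this assay.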